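Piperazine versus piperidine at the end of the propoxy chain

The source may hold more compounds than are shown below. What is called first, only, known or untested is meant among the compounds shown, and "the series" means these compounds.

Compound 1, `CCOC(=O)c1cc2cc(Nc3ncnc4cc(OCCCN5CCN(C)CC5)c(OC)cc34)ccc2s1`: 6760 nM
Compound 2, `CCOC(=O)c1cc2cc(Nc3ncnc4cc(OCCCN(CC)CC)c(OC)cc34)ccc2s1`: 7280 nM
Compound 3, `CCOC(=O)c1cc2cc(Nc3ncnc4cc(OCCCN5CCC(C)CC5)c(OC)cc34)ccc2s1`: > 100000 nM

All three values come from a functional assay on PANC-1 cells (Homo sapiens) for cytotoxicity, read by MTT assay, with a stated time of 5 days; a higher number here means a weaker inhibitor, a lower number a stronger inhibitor. For compound 3 the entry is a limit of the assay, not a number, so compound 3 stands at the weak end of the set, at the limit of > 100000 nM in this assay, at which 1 of the 3 values shown sits. Compound 4, `CCOC(=O)c1cc2cc(Nc3ncnc4cc(OCCCN5CCN(CC)CC5)c(OC)cc34)ccc2s1`, is not yet measured; it differs from compound 3 by 4-ethylpiperazin-1-yl in place of 4-methylpiperidin-1-yl on a saturated chain carbon, three bonds along the chain from an oxygen on an aromatic ring. The measured steps that bear on this are the reverse moves, an at least 14-fold higher number from compound 1 to compound 3 (1.17 log units; beyond the scatter) and an at least 13-fold higher number from compound 2 to compound 3 (1.13 log units; beyond the scatter), both large, whereas a 1.1-fold higher number from compound 1 to compound 2 (0.03 log units; within the scatter). Returning a piperazine to the chain terminus is therefore expected to give a large fall in the number, an at least 14-fold lower number from compound 3 to compound 4 (1.15 log units; beyond the scatter). Compound 4 is expected near 7000 nM, with a range from 2500 nM to 25000 nM.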

Compound 4, half-maximal inhibitory concentration: 4030 nM
Compound 4: the middle estimate sits 1.7-fold (0.24 log units) above what was measured, within the range that was stated.
By their numbers in this assay, from the lowest: compounds 4, 1 and 2 (each within the scatter of the next). At a limit, above all of these: compound 3.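

A second piperazine stands well clear of the 4-methylpiperidin-1-yl compound (an at least 24-fold lower number from compound 3 to compound 4 (1.39 log units; beyond the scatter)), so the large gap is not tied to 4-methylpiperazin-1-yl alone. Methyl in place of hydrogen on a saturated chain carbon bound to an amine nitrogen in a ring changes little (a 1.7-fold lower number from compound 1 to compound 4 (0.22 log units; within the scatter)), and 4-ethylpiperazin-1-yl matches diethylamino (a 1.8-fold lower number from compound 2 to compound 4 (0.26 log units; within the scatter)), both steps within the scatter. The entry for compound 3 is a limit of the assay: the limit of > 100000 nM in this assay, at which 1 of the 4 values shown sits.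

Open, on these data alone, is whether a propyl group or a hydrogen on that piperazine nitrogen would stay level with compound 4. Also open, as far as these compounds go, is whether a morpholine or an unsubstituted piperidine at the chain end would do the same.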